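This account rests on a few compounds, and the source may have more. Where it says the series, first, only, none or still open, it means among the compounds named here.

Compound 1 `CC(C)=CCOc1cccc(O)c1C(=O)/C=C/c1ccc(O)cc1`: > 30000 nM
Compound 2 `CCCCOc1cccc(O)c1C(=O)/C=C/c1ccc(O)cc1`: > 30000 nM

In a functional assay on MDA-MB-231 cells (Homo sapiens) for antiproliferative activity, read by sulforhodamine B assay (a higher number here means a weaker inhibitor of growth, a lower number a stronger inhibitor of growth), compound 1 gives > 30000 nM, which is a limit of the assay and not a number. Compound 2 gives > 30000 nM, which is also only a limit. This is the limit of > 30000 nM in this assay, at which 2 of the 2 values shown sit, so compound 2 has no measured potency to start from.

Compound 3 `O=C(/C=C/c1ccc(O)cc1)c1c(O)cccc1OCc1ccccc1` keeps the shared core and changes the chain: phenyl in place of propyl on a saturated chain carbon bound to an oxygen on an aromatic ring. In short, butoxy becomes benzyloxy. Going by the values given here, the only measured step bearing on this is a step that the two limits leave unreadable from compound 1 to compound 2, and it offers no size to carry over. Any real change could only show as stronger growth inhibition, and a modest one is expected: an at least 1.2-fold lower number from compound 2 to compound 3 (0.07 log units; that floor lies within the scatter) is the estimated step.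

Compound 3 is expected at about 25000 nM, with an estimated range of 10000 nM to 30000 nM.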

Compound 3, concentration for 50% growth inhibition: > 30000 nM
Compound 3 ended at the assay's limit; the forecaster's own chance of this, stated with the estimate: 65%; middle value at least 1.2-fold (0.07 log units) away from the limit.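

In this assay compound 3 gives > 30000 nM as a limit of the assay and not a number. The steps among compound 1, compound 2 and compound 3 therefore cannot be read. Left open is whether any group at this place would give this assay a measured number rather than a limit.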